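The compounds below may be only part of what the source reports. "The series", "measured", "known", "first", "only" and "open" are said of these compounds alone.

Compound 1 `Clc1nss/c1=N\c1ccc(OCc2ccccc2)cc1` gives 13000 nM in a functional assay on 5637 cells (Homo sapiens) for cytotoxicity, read by resazurin assay, with a stated time of 72 h; on this read-out higher numbers stand for weaker inhibition and lower numbers for stronger inhibition. Compound 2 `FC(F)(F)Oc1ccc(/N=c2\ssnc2Cl)cc1Br` gives 36000 nM. Compound 3 `Clc1nss/c1=N\c1cccc(Br)c1` gives 53000 nM.

Compound 3 holds the highest of the three numbers. Its nearest neighbour is compound 2, separated by a 1.5-fold higher number from compound 2 to compound 3 (0.17 log units; within the scatter), within the scatter; compound 1 lies further below, beyond the scatter. Compound 4 `N#Cc1c(Br)cccc1/N=c1\ssnc1Cl` differs from compound 3 by cyano in place of hydrogen on an aromatic carbon. Within the data shown here, the single measured step, a 1.5-fold higher number from compound 2 to compound 3 (0.17 log units; within the scatter), concerns a different group and stayed within the scatter; no measured step shows what cyano does at this place, so no shift beyond the scatter is expected in this assay. Compound 4 is therefore estimated at 40000 nM, within 15000 nM to 110000 nM, which means an expected step of a 1.3-fold lower number from compound 3 to compound 4 (0.12 log units; within the scatter).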

Compound 4, half-maximal inhibitory concentration: 14000 nM
For compound 4 the middle estimate is 2.9-fold (0.46 log units) above the measured one; measured number below the stated range.
By their numbers in this assay, from the lowest: compounds 1 and 4 (each within the scatter of the next); then compounds 2 and 3 (each within the scatter of the next).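

In this assay, cyano in place of hydrogen on an aromatic carbon, ortho to a bromo group, gives a 3.8-fold lower number from compound 3 to compound 4 (0.58 log units; beyond the scatter), so this position responds to a single change beyond the scatter. Among these compounds, the only earlier step, a 1.5-fold higher number from compound 2 to compound 3 (0.17 log units; within the scatter), concerned trifluoromethoxy and stayed within the scatter. Nothing available explains the drop with cyano. From the compounds shown here alone, whether an amine or a carboxylic acid at this place would lower the number as well remains open. So does whether cyano would give a similar step without the bromo group.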